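Swapping the Aryl on the Piperazine Nitrogen

The compounds below may be only part of what the source reports. "The series", "measured", "known", "first", "only" and "open" are said of these compounds alone.

Compound 1 `COc1ccccc1N1CCN(Cn2nc(-c3ccc4c(c3)OCCO4)oc2=S)CC1`, compound 2 `Fc1ccc(N2CCN(Cn3nc(-c4ccc5c(c4)OCCO5)oc3=S)CC2)cc1` and compound 3 `S=c1oc(-c2ccc3c(c2)OCCO3)nn1CN1CCN(c2ccccn2)CC1` share one core and differ only in the aryl group on an amine nitrogen in a ring. In a functional assay on HeLa cells (Homo sapiens) for antiproliferative activity, read by MTT assay, with a stated time of 48 h (on this read-out lower numbers stand for stronger inhibition and higher numbers for weaker inhibition), compound 1 returns only a limit, > 50000 nM. Compound 2 likewise returns only a limit in this assay, namely > 50000 nM. Among the measured compounds shown here, compound 3 is the single compound with a number in this assay, giving 25100 nM, while the other two sit at the limit of > 50000 nM in this assay, at which 2 of the 3 values shown sit. The readable steps of an at least 1.9-fold lower number from compound 1 to compound 3 (0.29 log units; that floor lies within the scatter) and an at least 1.9-fold lower number from compound 2 to compound 3 (0.29 log units; that floor lies within the scatter) both lowered the number on the way to compound 3, whereas a step that the two limits leave unreadable from compound 1 to compound 2. Compound 4 `S=c1oc(-c2ccc3c(c2)OCCO3)nn1CN1CCN(c2ccccc2Cl)CC1` carries 2-chlorophenyl in place of pyridin-2-yl on an amine nitrogen in a ring, a return to a carbon-only aryl group. Compound 4 is therefore expected at 40000 nM, between 15000 nM and 100000 nM, which would mean a 1.6-fold higher number from compound 3 to compound 4 (0.20 log units; within the scatter).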

Compound 4, half-maximal inhibitory concentration: 37400 nM
Compound 4: middle estimate off by 1.1-fold (0.03 log units), on the high side, within the range that was stated.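

Compound 4 shows that a carbon-only aryl group on this amine nitrogen in a ring can still give a number in this assay, so the ring nitrogen of pyridin-2-yl is not needed for one, with a 1.5-fold higher number from compound 3 to compound 4 (0.17 log units; within the scatter). Against the two limits, an at least 1.3-fold lower number from compound 2 to compound 4 (0.12 log units; that floor lies within the scatter) and an at least 1.3-fold lower number from compound 1 to compound 4 (0.12 log units; that floor lies within the scatter) give only floors, and neither floor goes beyond the scatter. Compound 1 and compound 2 remain limits, not numbers: the limit of > 50000 nM in this assay, at which 2 of the 4 values shown sit.

Left open is whether a benzyl or a methyl group on this nitrogen, in place of a directly attached aromatic ring, would give a number in this assay.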